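Two nitrate esters of a shared core and an untested third

The source may report more compounds than this note shows. Statements on the series, on what has been measured and on what is new or still open speak of the compounds shown alone.

Compound 1, `Cc1cc(OC(=O)OCCCCC(CO[N+](=O)[O-])O[N+](=O)[O-])n(-c2ccccc2)n1`, gives < 0.0167 h in an ADME assay on a cell-free system (serum, Homo sapiens) for metabolic stability, read by HPLC, tested at 250 uM; on this read-out higher numbers stand for a longer-lived compound and lower numbers for a shorter-lived compound.
Compound 2, `Cc1cc(OC(=O)C(C)(C)CCCCO[N+](=O)[O-])n(-c2ccccc2)n1`, gives 0.222 h in this assay.
Compound 3, `Cc1cc(OC(=O)CCCCCO[N+](=O)[O-])n(-c2ccccc2)n1`, gives < 0.0167 h in this assay.

Compound 1 stands on a limit of this assay, not on a number: it is one of the two of three values that sit at the limit of < 0.0167 h in this assay, at which 2 of the 3 values shown sit. Compound 3 likewise returns only a limit in this assay. Among the measured compounds shown here, of the three measured, only compound 2 yields a number in this assay, and no pair of measured compounds differs in a single place, so no measured step can be drawn.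

Compound 4, `Cc1cc(OC(=O)OCCCCCCO[N+](=O)[O-])n(-c2ccccc2)n1`, has not been measured. It differs from compound 1 by hydrogen in place of nitrooxy on a saturated chain carbon bound to two saturated chain carbons. Cut one bond further out, the same change reads as 1,2-bis(nitrooxy)ethyl to 2-(nitrooxy)ethyl.

For the measured compounds named here, with no measured step of this kind to lean on, and compound 1 sitting at the limit of < 0.0167 h in this assay, at which 2 of the 3 values shown sit, no direction beyond the scatter is expected in this assay; the estimated step of an at least 1.1-fold higher number from compound 1 to compound 4 (0.07 log units; that floor lies within the scatter) is small. Compound 4 is therefore estimated at 0.02 h, between 0.005 h and 0.1 h, with a fair chance that only a limit is reported again.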

Compound 4, half-life in the serum assay: < 0.0167 h
Compound 4: only a limit was reported; the forecaster's own chance of this, stated with the estimate: 55%; middle value at least 1.1-fold (0.07 log units) away from the limit.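

Among the compounds shown here, compound 1 and compound 4 both return only a limit in the serum assay, so no step between them can be read there. In a physicochemical assay for metabolic stability, read by HPLC (a lower number here means that the compound disappears faster, a higher number that the compound lasts longer), compound 1 gives 6 h and compound 4 gives 25 h. Hydrogen in place of nitrooxy there gives a 4.2-fold higher number from compound 1 to compound 4 (0.62 log units; beyond the scatter). Going by these compounds, whether that change shifts the half-life in the serum assay stays open.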